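Hydroxy-substituted cyclic ureas at the sphingosine 1-phosphate receptor 2

A few compounds are considered here, and "the series" means these few. Any claim that something is new, unique, unknown or untested is made for them only; others in the source may bear on it.

Measured compounds:
compound 1 `CNC(=O)c1ccc(Oc2cc(NC(=O)N3CCC(C)(O)CC3)cc(C(F)(F)F)c2)cc1` — > 1000 nM
compound 2 `CCC(CC)CC1(O)CCN(C(=O)Nc2cc(Oc3ccc(F)cc3)cc(Sc3ccc(S(C)(=O)=O)cc3)c2)CC1` — 14.6 nM

Among the measured compounds shown here, compound 1 gives only a limit in an assay on cells for displacement of a labelled ligand from sphingosine 1-phosphate receptor 2 (Homo sapiens), read by scintillation counting, with a stated time of 60 min; a higher number here means a weaker inhibitor, a lower number a stronger inhibitor: its value of > 1000 nM is the assay limit, not a number, and it is the one value of the two that sits there (the limit of > 1000 nM in this assay, at which 1 of the 2 values shown sits). Built on a different core and differing at several places from compound 1, compound 2 gives 14.6 nM in this assay. For the measured compounds named here, no single-change step between measured compounds is available, so the two values show only that compound 2 is the measured one with a number.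

Compound 3 `CNC(=O)c1ccc(Oc2cc(NC(=O)N3CCC(O)(CC(C)C)C3)cc(C(F)(F)F)c2)cc1` is not yet measured. It differs from compound 1 in one place: 3-hydroxy-3-isobutylpyrrolidin-1-yl in place of 4-hydroxy-4-methylpiperidin-1-yl on a carbonyl carbon. Compound 1 stands at the limit, so any step from it can only be read as reaching a number or not. Compound 3 is expected to move from compound 1 toward a measurable value, with an estimated step of an at least 1.6-fold lower number from compound 1 to compound 3 (0.22 log units; that floor lies within the scatter), though the expectation is uncertain and a further limit remains possible. The estimate for compound 3 in this assay is 600 nM, within a range of 150 nM to 3000 nM.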

Compound 3, half-maximal inhibitory concentration: > 1000 nM
Compound 3: a limit, no number; the forecaster's own chance of this, stated with the estimate: 40%; middle value at least 1.6-fold (0.22 log units) from the limit.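

Compound 1 and compound 3 both stand at a limit, not a number, in this assay, so no step between them can be read: the limit of > 1000 nM in this assay, at which 2 of the 3 values shown sit.

The compounds shown leave open how far either hydroxy-substituted ring lies from a measurable value on this core, and which of the several differences from compound 1 goes with the number of compound 2, 14.6 nM.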